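The source may hold more compounds than are shown below. What is called first, only, known or untested is meant among the compounds shown, and "the series" means these compounds.

Compound 1 `COC(=O)c1c(Br)cc(Br)cc1OC(=O)COc1cc(O)c2c(=O)cc(-c3ccccc3)oc2c1` gives 398000 nM in an ADME assay on cells (T-cell, Mus musculus, strain BALB/c) for cytotoxicity, read by MTT assay, with a stated time of 48 h; a lower number here means that less compound is tolerated, a higher number that more compound is tolerated. Compound 2 `COC(=O)c1c(Br)cccc1OC(=O)COc1cc(O)c2c(=O)cc(-c3ccccc3)oc2c1` gives 388000 nM in this assay. Compound 3 `COC(=O)c1cc(Br)ccc1OC(=O)COc1cc(O)c2c(=O)cc(-c3ccccc3)oc2c1` reaches only the limit of > 450000 nM in this assay.

Compound 3 thus stands at the limit of > 450000 nM in this assay, at which 1 of the 3 values shown sits, with no number of its own. Compound 4 `COC(=O)c1ccc(Br)cc1OC(=O)COc1cc(O)c2c(=O)cc(-c3ccccc3)oc2c1` differs from it by a group of 11 heavy atoms (8 carbon, 2 oxygen, 1 bromine; one six-membered aromatic ring of carbon only) in place of a group of 11 heavy atoms (8 carbon, 2 oxygen, 1 bromine; one six-membered aromatic ring of carbon only), on an oxygen next to a carbonyl group. Among the compounds with values here, two measured steps bear on this: a 1.0-fold lower number from compound 1 to compound 2 (0.01 log units; within the scatter) and an at least 1.1-fold higher number from compound 2 to compound 3 (0.06 log units; that floor lies within the scatter), the second being the same kind of swap on the oxygen next to the carbonyl group. Both lie within the scatter, so no step beyond the scatter is expected in this assay, in either direction. Compound 4 is therefore expected at 430000 nM, between 300000 nM and 600000 nM, an expected step of an at least 1.0-fold lower number from compound 3 to compound 4 (0.01 log units; that floor lies within the scatter).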

Compound 4, half-maximal cytotoxic concentration: 326000 nM
Compound 4: middle estimate off by 1.3-fold (0.12 log units), on the high side; low and high end bracket the measured number.
By their numbers in this assay, from the lowest: compounds 4, 2 and 1 (each within the scatter of the next). At a limit, above all of these: compound 3.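

Placing the bromo and methoxycarbonyl groups differently on the ring attached to the oxygen next to a carbonyl group gives an at least 1.3-fold lower number from compound 3 to compound 4 (0.13 log units; that floor lies within the scatter). Compound 3 has only a limit, not a number: the limit of > 450000 nM in this assay, at which 1 of the 4 values shown sits. Among the measured numbers in this assay, the same kind of rearrangement gives a 1.2-fold lower number from compound 2 to compound 4 (0.08 log units; within the scatter), and hydrogen in place of bromo gives a 1.2-fold lower number from compound 1 to compound 4 (0.09 log units; within the scatter), so no change of bromo arrangement shown here leaves the scatter.

From the compounds shown here alone, whether an amine or a carboxylic acid on this ring would move the number beyond the scatter remains open. Going by these compounds, how far compound 3 lies beyond its limit also remains open.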